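Replacing an amide-linked aryl by a direct nitroaryl on the ring nitrogen

The compounds below may be only part of what the source reports. "The series", "measured", "known", "first", "only" and "open" are said of these compounds alone.

The series shares one core and varies the group on an aromatic nitrogen of a five-membered aromatic ring with 3 nitrogen. Compound 1 `CCOC(=O)C1=Cc2ccccc2OC1(OCc1cn(-c2ccc(F)cc2)nn1)C(F)(F)F` carries 4-fluorophenyl there and in a functional assay on A549 cells (Homo sapiens) for inhibition, read by MTT assay, with a stated time of 24 h (on this read-out lower numbers stand for stronger inhibition and higher numbers for weaker inhibition), compound 1 gives 7300 nM. Compound 2 `CCOC(=O)C1=Cc2ccccc2OC1(OCc1cn(CC(=O)Nc2ccc(C)cc2)nn1)C(F)(F)F` carries ((4-methylphenyl)carbamoyl)methyl and gives 54300 nM. Compound 3 `CCOC(=O)C1=Cc2ccccc2OC1(OCc1cn(CC(=O)Nc2ccc(I)cc2Cl)nn1)C(F)(F)F` carries ((2-chloro-4-iodophenyl)carbamoyl)methyl and gives 22300 nM, which is the second highest of the three numbers. The steps of a 7.4-fold higher number from compound 1 to compound 2 (0.87 log units; beyond the scatter) and a 3.1-fold higher number from compound 1 to compound 3 (0.48 log units; beyond the scatter) show that moving from an aryl directly on the ring nitrogen to a carbamoylmethyl-linked aryl raised the number, while a 2.4-fold lower number from compound 2 to compound 3 (0.39 log units; beyond the scatter) shows a smaller shift between the two amide-linked aryls.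

Compound 4 `CCOC(=O)C1=Cc2ccccc2OC1(OCc1cn(-c2ccc([N+](=O)[O-])cc2)nn1)C(F)(F)F` is not yet measured. It differs from compound 3 as follows: 4-nitrophenyl in place of ((2-chloro-4-iodophenyl)carbamoyl)methyl on an aromatic nitrogen. This change returns to an aryl placed directly on the ring nitrogen, the arrangement seen in compound 1, so the step of a 3.1-fold higher number from compound 1 to compound 3 (0.48 log units; beyond the scatter) bears most directly on it and is expected to run in reverse. The difference between 4-nitrophenyl and 4-fluorophenyl is not covered by any measured pair, so the return is expected to be incomplete. Compound 4 is therefore estimated at 9000 nM, with a range from 3000 nM to 27000 nM, which corresponds to an expected step of a 2.5-fold lower number from compound 3 to compound 4 (0.39 log units; beyond the scatter).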

Compound 4, half-maximal inhibitory concentration: > 150000 nM
Compound 4 gave a limit, no number; the forecaster's own chance of this, stated with the estimate: 5%; middle value at least 16-fold (1.22 log units) away from the limit.
By their numbers in this assay, from the lowest: compound 1; then compound 3; then compound 2. At a limit, above all of these: compound 4.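

In this assay compound 4 gives > 150000 nM, which is a limit of the assay and not a number, and every comparison with it rests on that limit: the limit of > 150000 nM in this assay, at which 1 of the 4 values shown sits.

Among these compounds, with the aryl still directly on the ring nitrogen, exchanging fluoro for nitro on an aromatic carbon gives an at least 20-fold higher number from compound 1 to compound 4 (1.31 log units; beyond the scatter), a larger step than any among the earlier compounds, so the direct attachment alone does not carry the lower number. The earlier trend of lower numbers for a directly attached aryl than for a carbamoylmethyl-linked aryl therefore holds for compound 1 only, and 4-nitrophenyl runs against it, with an at least 6.7-fold higher number from compound 3 to compound 4 (0.82 log units; beyond the scatter) and an at least 2.7-fold higher number from compound 2 to compound 4 (0.44 log units; beyond the scatter).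

The compounds shown carry only fluoro and nitro on a directly attached aryl, so it stays open how an amine or a carboxylic acid in that place would read. They also leave open whether nitro on a carbamoylmethyl-linked aryl would give a similar rise, and nothing shown tells why the number rose.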